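The source may hold more compounds than are shown below. What is called first, only, known or untested is meant among the compounds shown, and "the series" means these compounds.

Measured compounds in the series:

Compound 1, `COc1cc(Cc2nc3c(N)ncnc3n2CC2CCCCC2)cc(OC)c1OC`: 39800 nM in a functional assay on MCF7 cells (Homo sapiens) for antiproliferative activity; on this read-out lower numbers stand for stronger inhibition and higher numbers for weaker inhibition
Compound 2, `CC/C=C/Cn1c(Cc2cc(OC)c(OC)c(OC)c2)nc2c(N)ncnc21`: 46800 nM in this assay

Compound 2 carries the higher of the two numbers, but the gap to compound 1 is small: a 1.2-fold higher number from compound 1 to compound 2 (0.07 log units; within the scatter). The two compounds therefore cannot be ranked against each other; both sit at the weak end of this assay.

Compound 3, `CCCn1c(Cc2cc(OC)c(OC)c(OC)c2)nc2c(N)ncnc21`, has not yet been measured. It differs from compound 2 in one place: ethyl in place of but-1-en-1-yl on a saturated chain carbon bound to an aromatic nitrogen. Going by the values given here, the only measured step that bears on this position is the one from compound 1 to compound 2, where one group on the same saturated chain carbon was exchanged for another with no effect beyond the scatter (a 1.2-fold higher number from compound 1 to compound 2 (0.07 log units; within the scatter)). Among the compounds with values here, no measured step shows the shorter group now entering, so the series offers no direct precedent for it. Within the data shown here, on the one comparison available, the change is expected to leave this assay essentially unmoved: a 1.0-fold lower number from compound 2 to compound 3 (0.02 log units; within the scatter). Compound 3 is accordingly estimated at 45000 nM, with a range from 18000 nM to 110000 nM.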

Compound 3, half-maximal inhibitory concentration: 46800 nM
The estimate for compound 3 lay 1.0-fold (0.02 log units) below the measured number; measured number inside the range.
By their numbers in this assay, from the lowest: compounds 1, 2 and 3 (each within the scatter of the next).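

Exchanging but-1-en-1-yl for ethyl on a saturated chain carbon bound to an aromatic nitrogen gives no change at the digits printed from compound 2 to compound 3 (within the scatter) in this assay and thus removes both the double bond outside aromatic rings and two of the four carbons without separating the two compounds. The comparison with the ring-bearing compound gives a 1.2-fold higher number from compound 1 to compound 3 (0.07 log units; within the scatter) for ethyl in place of cyclohexyl, so a ring, an alkene chain and a short saturated chain at this place all remain within the scatter of one another, and none of the three compounds goes against this. What the earlier pair could not show is that this flat reading extends to a smaller group with no ring and no double bond, though the data offer no explanation for it.

From the compounds shown here alone, all three groups here consist of carbon and hydrogen only, so it remains open whether an amine, a carboxylic acid or a hydroxyl group at this place would shift the number in this assay beyond the scatter. Going by these compounds, it is also open whether a longer chain such as octyl, or an exchange elsewhere on the shared core, would separate compounds.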